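The source may report more compounds than this note shows. Statements on the series, on what has been measured and on what is new or still open speak of the compounds shown alone.

In a functional assay on the whole organism with Rattus norvegicus as the target (a higher number here means that more compound is needed for the effect, a lower number that less compound is needed), compound 1 `CCOC(=O)C(=O)Nc1nc(-c2ccc(O)cc2)cs1` gives about 15 mg/kg. Compound 2 `CCOC(=O)C(=O)Nc1nc(-c2ccc([N+](=O)[O-])cc2)cs1` gives > 100 mg/kg, which is only a limit of the assay and not a number. Compound 3 `CCOC(=O)C(=O)Nc1nc(-c2ccc(N(C)C)cc2)cs1` differs from compound 2 by dimethylamino in place of nitro on an aromatic carbon, with dimethylamino in place of nitro on an aromatic carbon. A single measured step bears on this change: nitro in place of hydroxy on an aromatic carbon, an at least 6.6-fold higher number from compound 1 to compound 2 (0.82 log units; beyond the scatter), which lies beyond the scatter. Removing the nitro is therefore expected to lower the number, though dimethylamino is not hydroxy and the guide is thin. The expected step is an at least 2.8-fold lower number from compound 2 to compound 3 (0.45 log units; beyond the scatter). For compound 3 the estimate is 35 mg/kg, within an expected range of 12 mg/kg to 100 mg/kg.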

Compound 3, dose for half-maximal effect: about 1 mg/kg
For compound 3 the middle estimate is 35-fold (1.54 log units) above the measured one; measured number below the stated range.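

Dimethylamino in place of nitro gives an at least 100-fold lower number from compound 2 to compound 3 (2.00 log units; beyond the scatter). Dimethylamino in place of hydroxy gives a 15-fold lower number from compound 1 to compound 3 (1.18 log units; beyond the scatter), so at this position on the aromatic ring, dimethylamino needs less compound than either earlier group, rather than merely matching hydroxy. The first step rests on compound 2, whose value is only a limit of the assay: the limit of > 100 mg/kg in this assay, at which 1 of the 3 values shown sits.

The compounds shown leave open whether a plain amino group, a methoxy group or a longer dialkylamino group such as diethylamino would serve as well here. They also do not tell why dimethylamino gives the lowest number of the three.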